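The source may report more compounds than this note shows. Statements on the series, on what has been measured and on what is new or still open speak of the compounds shown alone.

Measured compounds:
- Compound 1 `O=C(/C=C/c1ccc([N+](=O)[O-])cc1)c1ccc(O)c(O)c1` gives 5800 nM
- Compound 2 `Nc1ccc(C(=O)/C=C/c2ccco2)cc1` gives 21000 nM

In a functional assay on HCT-116 cells (Homo sapiens) for cytotoxicity, read by resazurin assay, with a stated time of 48 h (a higher number here means that more compound is needed for the effect, a lower number that less compound is needed), compound 1 gives 5800 nM, while compound 2 gives 21000 nM. Of the two numbers, compound 2 stands highest; its nearest neighbour is compound 1, whose number is lower by a gap beyond the usual scatter, so more of compound 2 is needed for the effect than of compound 1. Among the compounds with values here, the two compounds differ in several places at once, so no single step between measured compounds is available from which to read the influence of one change.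

Compound 3 `O=C(/C=C/c1ccco1)c1ccc(NC(=O)c2ccccc2)cc1` differs from compound 2 in a single place: benzoyl in place of hydrogen on a nitrogen on an aromatic ring. Within the data shown here, since no measured pair separates this change out, the expectation for compound 3 rests on the value of compound 2 alone, and the step is expected to be no larger than the scatter in either direction. Compound 3 is therefore expected to give about 15000 nM in this assay, within a range from 4000 nM to 55000 nM; this means an expected step of a 1.4-fold lower number from compound 2 to compound 3 (0.15 log units; within the scatter), which would not be beyond the scatter.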

Compound 3, half-maximal effective concentration: 42000 nM
For compound 3 the middle estimate is 2.8-fold (0.45 log units) below the measured one, and the stated range covers the measured number.
By their numbers in this assay, from the lowest: compound 1; then compounds 2 and 3 (each within the scatter of the next).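

Within the data shown here, this is the first step that isolates a single change: in this assay, benzoyl in place of hydrogen on a nitrogen on an aromatic ring gives a 2.0-fold higher number from compound 2 to compound 3 (0.30 log units; within the scatter) and so stays within the usual scatter of repeated measurements. It shows that this nitrogen can carry benzoyl, which adds 8 heavy atoms including one six-membered aromatic ring, with no step beyond that scatter, so this single comparison gives no sign that the change matters for the number in this assay. No measurement shown here offers a reason for this result.

The compounds shown leave open whether a smaller group on the same nitrogen, such as acetyl or methyl, or a different one, such as methanesulfonyl, would give a step beyond the scatter. They also leave open which of the several places that separate compound 1 from compound 2 and compound 3 accounts for the lower number of compound 1, since those comparisons span more than one change and cannot be read as single steps.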